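From Iodo to Cyano Among Compounds at the Limit

A few compounds are considered here, and "the series" means these few. Any claim that something is new, unique, unknown or untested is made for them only; others in the source may bear on it.

Compound 1 (`Cc1ccccc1-c1noc([C@@H]2CCCN2C(=O)Nc2ccc(Cl)cc2)n1`), compound 2 (`N#Cc1cccc(-c2noc([C@@H]3CCCN3C(=O)Nc3ccc(Cl)cc3)n2)c1`) and compound 3 (`O=C(Nc1ccc(Cl)cc1)N1CCC[C@H]1c1nc(-c2ccc(I)cc2)no1`) share one core. In an ADME assay on MCF-10A cells (Homo sapiens) for inhibition, with a stated time of 48 h (on this read-out lower numbers stand for stronger inhibition and higher numbers for weaker inhibition), compound 1 gives > 50000 nM as a limit. Compound 2 gives > 50000 nM as a limit too. Compound 3 gives > 50000 nM as a limit as well. Compound 3 thus stands with the other two at the limit of > 50000 nM in this assay, at which 3 of the 3 values shown sit, and has no exact number. Compound 4 (`N#Cc1ccc(-c2noc([C@@H]3CCCN3C(=O)Nc3ccc(Cl)cc3)n2)cc1`) carries cyano in place of iodo on an aromatic carbon. Among the compounds with values here, two measured steps bear on this change: a step that the two limits leave unreadable from compound 2 to compound 3 and a step that the two limits leave unreadable from compound 1 to compound 3 and neither gives a size. No step beyond the scatter is therefore expected in this assay and no direction can be assigned. The expected change is a number no higher from compound 3 to compound 4 (the limit leaves the size open) for this exchange. Compound 4 is estimated at 50000 nM (range 20000 nM to 100000 nM) and will probably be reported as a limit again.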

Compound 4, half-maximal inhibitory concentration: > 50000 nM
Compound 4 ended at the assay's limit; the forecaster's own chance of this, stated with the estimate: 85%; the middle value sits exactly at the limit.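

No new step can be read between compound 4 and compound 1, compound 2 or compound 3 in this assay as all four values are limits. The compounds shown leave open whether in this assay the exchanged aromatic groups differ at all.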